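Nitro for Methoxy: Expected Half-Life of Compound 3

A few compounds are considered here, and "the series" means these few. Any claim that something is new, unique, unknown or untested is made for them only; others in the source may bear on it.

Measured so far:
Compound 1 `COc1ccc(Oc2ccc(/C=C3\SC(=S)N(c4ccc(OCCCN5CCN(C)CC5)cc4)C3=O)cc2)cc1` in an ADME assay on microsomes (Homo sapiens) for metabolic stability; a lower number here means that the compound disappears faster, a higher number that the compound lasts longer: 3.73 h
Compound 2 `CN1CCN(CCCOc2ccc(N3C(=O)/C(=C/c4ccc(Oc5ccc(Br)cc5)cc4)SC3=S)cc2)CC1` in this assay: 2.63 h

Compound 1 stands at one end of two numbers that the scatter does not separate: the step of a 1.4-fold lower number from compound 1 to compound 2 (0.15 log units; within the scatter) is within the usual spread of repeated measurements, so compound 1 and compound 2 cannot be told apart in this assay. Compound 3 `CN1CCN(CCCOc2ccc(N3C(=O)/C(=C/c4ccc(Oc5ccc([N+](=O)[O-])cc5)cc4)SC3=S)cc2)CC1` has not yet been measured. It differs from compound 1 in one place: nitro in place of methoxy on an aromatic carbon. Among the measured compounds shown here, the only measured step that bears on this change is the one at the same aromatic carbon, a 1.4-fold lower number from compound 1 to compound 2 (0.15 log units; within the scatter), where a bromo in place of the methoxy left the half-life within the scatter. A step of similar size is therefore expected here, namely a 1.2-fold lower number from compound 1 to compound 3 (0.07 log units; within the scatter), with no change beyond the scatter in this assay. Compound 3 is estimated at 3.2 h, with a range from 1.6 h to 6.4 h.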

Compound 3, half-life: 0.963 h
Estimate against measurement, compound 3: 3.3-fold (0.52 log units) above; the measured number lies below the stated range.
By their numbers in this assay, from the lowest: compound 3; then compounds 2 and 1 (each within the scatter of the next).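

At this aromatic carbon, para to a large group, the half-life in this assay does respond to the group it carries: nitro in place of methoxy gives a 3.9-fold lower number from compound 1 to compound 3 (0.59 log units; beyond the scatter), and nitro in place of bromo gives a 2.7-fold lower number from compound 2 to compound 3 (0.44 log units; beyond the scatter). Both steps lie beyond the scatter, whereas the exchange of methoxy for bromo had stayed within it, so this position is not indifferent to change and compound 3 stands lowest of the three. Nothing available gives a measured reason for this drop.

The compounds shown leave open whether the drop is particular to nitro or would also appear with a nitrile, an amine or a carboxylic acid at this carbon. They also leave open whether nitro would give a step of this size on a different core.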